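The source may hold more compounds than are shown below. What is called first, only, known or untested is meant among the compounds shown, and "the series" means these compounds.

In an assay on CHO cells for displacement of a labelled ligand from Substance-P receptor (Homo sapiens), in the presence of a further agent that is not named here (a higher number here means a weaker inhibitor, a lower number a stronger inhibitor), the three measured compounds stand as follows:
compound 1 `C[C@@H](O[C@H]1CN2C(=O)C=C(c3ccc(NS(C)(=O)=O)cc3)CC2[C@@H]1c1ccc(F)cc1)c1cc(C(F)(F)F)cc(C(F)(F)F)c1`, 54 nM
compound 2 `C[C@@H](O[C@H]1CN2C(=O)C=C(c3ccncc3)CC2[C@@H]1c1ccc(F)cc1)c1cc(C(F)(F)F)cc(C(F)(F)F)c1`, 8.1 nM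
compound 3 `C[C@@H](O[C@H]1CN2C(=O)C=C(c3cnn(C)c3)CC2[C@@H]1c1ccc(F)cc1)c1cc(C(F)(F)F)cc(C(F)(F)F)c1`, 5.4 nM

Compound 3 sits at the low end of these numbers, but its gap to compound 2 lies within the scatter, so those two cannot be set in order; only its gap to compound 1 is clear, a 10-fold lower number from compound 1 to compound 3 (1.00 log units; beyond the scatter). Compound 4 `C[C@@H](O[C@H]1CN2C(=O)C=C(C3=CCC(O)CC3)CC2[C@@H]1c1ccc(F)cc1)c1cc(C(F)(F)F)cc(C(F)(F)F)c1` has not yet been measured. It differs from compound 3 in one place: 4-hydroxycyclohex-1-en-1-yl in place of 1-methyl-1H-pyrazol-4-yl on a double-bonded ring carbon. The steps that touch this position are a 6.7-fold lower number from compound 1 to compound 2 (0.82 log units; beyond the scatter) and a 10-fold lower number from compound 1 to compound 3 (1.00 log units; beyond the scatter), both beyond the scatter, and a 1.5-fold lower number from compound 2 to compound 3 (0.18 log units; within the scatter), within it. All three compare aromatic rings with one another; none trades an aromatic ring for a non-aromatic ring carrying a hydroxyl, so they offer no direct guide. Given that the two heteroaromatic groups gave close numbers while the substituted phenyl gave a weaker result, a modest move toward a weaker inhibitor is expected for compound 4, a 2.8-fold higher number from compound 3 to compound 4 (0.44 log units; beyond the scatter). The estimate for compound 4 is 15 nM, within a range of 4 nM to 60 nM.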

Compound 4, half-maximal inhibitory concentration: 13 nM
The estimate for compound 4 lay 1.2-fold (0.06 log units) above the measured number; low and high end bracket the measured number.
By their numbers in this assay, from the lowest: compounds 3, 2 and 4 (each within the scatter of the next, the first and the last beyond it); then compound 1.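

In this assay this position accepts a non-aromatic ring, which the aromatic groups alone could not show: 4-hydroxycyclohex-1-en-1-yl gives a 1.6-fold higher number from compound 2 to compound 4 (0.21 log units; within the scatter) against pyridin-4-yl, so those two cannot be set in order, and a 4.2-fold lower number from compound 1 to compound 4 (0.62 log units; beyond the scatter) against 4-(methanesulfonamido)phenyl. Against 1-methyl-1H-pyrazol-4-yl the same group gives a 2.4-fold higher number from compound 3 to compound 4 (0.38 log units; beyond the scatter), a modest weakening, so an aromatic ring is not needed here for a low number, though the pyrazole remains ahead of the hydroxylated ring. Nothing available explains these differences. Going by these compounds, it remains open whether the hydroxyl contributes at all, which a plain cyclohex-1-en-1-yl ring would test. An amine or a carboxylic acid in place of the hydroxyl would show how much that ring position tolerates.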